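The source may report more compounds than this note shows. Statements on the series, on what has been measured and on what is new or still open speak of the compounds shown alone.

Two pairs in this small set share one structural change. Compound 1 `CC(=O)Nc1n[nH]c2cc(-c3cn([C@@H]4CN[C@H](C(=O)Nc5ccc(Br)cc5)C4)nn3)ccc12` carries an acetamido group on its core, and in a functional assay on K562 cells (Homo sapiens) for inhibition, read by MTT assay, with a stated time of 48 h (on this read-out lower numbers stand for stronger inhibition and higher numbers for weaker inhibition), compound 1 gives 3830 nM. Compound 2 `O=C(Nc1n[nH]c2cc(-c3cn([C@@H]4CN[C@H](C(=O)Nc5ccc(Br)cc5)C4)nn3)ccc12)C1CC1` differs from it by cyclopropyl in place of methyl on a carbonyl carbon; in this assay compound 2 gives 8080 nM, a step of a 2.1-fold higher number from compound 1 to compound 2 (0.32 log units; beyond the scatter). Compound 3 `CC(=O)Nc1nc2ccc(-c3cn([C@@H]4CN[C@H](C(=O)Nc5ccc(Br)cc5)C4)nn3)nc2s1` is built on a different core, and the difference between the two cores is not broken down here; in this assay compound 3 gives 5020 nM, which lies within the scatter of compound 1. Compound 4 `O=C(Nc1nc2ccc(-c3cn([C@@H]4CN[C@H](C(=O)Nc5ccc(Br)cc5)C4)nn3)nc2s1)C1CC1` differs from compound 3 by cyclopropyl in place of methyl on a carbonyl carbon, the same change at the same place. Because the earlier pair showed a 2.1-fold higher number from compound 1 to compound 2 (0.32 log units; beyond the scatter), a step of similar size is expected, a 2.1-fold higher number from compound 3 to compound 4 (0.32 log units; beyond the scatter). Compound 4 is therefore estimated at 10500 nM, expected to fall between 5000 nM and 22000 nM.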

Compound 4, half-maximal inhibitory concentration: 8160 nM
Beside the measured number, compound 4's estimate is 1.3-fold (0.11 log units) above it; the range from low to high includes it.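

In this assay, cyclopropyl in place of methyl on a carbonyl carbon gives a 1.6-fold higher number from compound 3 to compound 4 (0.21 log units; within the scatter), so on this core the step cannot be told apart from the usual scatter. Set beside the step on the other core, it does not differ: the same change on two cores in this assay, a 2.1-fold higher number (0.32 log units; beyond the scatter) from compound 1 to compound 2 and a 1.6-fold higher number (0.21 log units; within the scatter) from compound 3 to compound 4, 1.3-fold (0.11 log units) apart, within the scatter of two such steps. The change therefore carries from one core to the other with no detectable difference in step size, but two pairs give no rule for other cores, and only the first step by itself stands beyond the scatter. The compounds shown leave open how a longer chain such as propyl, or a phenyl group, would behave in place of cyclopropyl. They also leave open what a free amine would give in place of the acetamido group on either core.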